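Replacing Cycloheptyl with Acetylpiperidinyl on the Ring Nitrogen

The compounds below may be only part of what the source reports. "The series", "measured", "known", "first", "only" and "open" are said of these compounds alone.

Three measured compounds share one core and differ only in the group on an aromatic nitrogen. Compound 1 `CC(C)c1onc(-c2c(Cl)cccc2Cl)c1COc1ccc(-c2nc3ccc(C(=O)O)cc3n2Cc2ccc(F)cc2)cc1` gives 1140 nM in an assay on HEK-293T cells for antagonist activity at vitamin D3 receptor (Homo sapiens), read by a luciferase reporter, with a stated time of 24 h; on this read-out lower numbers stand for stronger inhibition and higher numbers for weaker inhibition. Compound 3 `CC(C)c1onc(-c2c(Cl)cccc2Cl)c1COc1ccc(-c2nc3ccc(C(=O)O)cc3n2C2CCCCCC2)cc1` gives 921 nM in this assay, the lowest of the two numbers, although the step of a 1.2-fold lower number from compound 1 to compound 3 (0.09 log units; within the scatter) lies within the scatter. Compound 2 `CCCC(CCC)n1c(-c2ccc(OCc3c(-c4c(Cl)cccc4Cl)noc3C(C)C)cc2)nc2ccc(C(=O)O)cc21` reaches only the limit of this assay, > 10000 nM (the limit of > 10000 nM in this assay, at which 1 of the 3 values shown sits).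

Compound 4 `CC(=O)N1CCC(n2c(-c3ccc(OCc4c(-c5c(Cl)cccc5Cl)noc4C(C)C)cc3)nc3ccc(C(=O)O)cc32)CC1` differs from compound 3 by 1-acetylpiperidin-4-yl in place of cycloheptyl on an aromatic nitrogen. Going by the values given here, two steps bear on this change: a branched open chain on this nitrogen gave the large step of an at least 10-fold lower number from compound 2 to compound 3 (1.03 log units; beyond the scatter), whereas the ring-bearing groups sit close together, as the step of a 1.2-fold lower number from compound 1 to compound 3 (0.09 log units; within the scatter) shows. The incoming group keeps a ring on the nitrogen, so a large loss is not expected, but its shape and acceptor differ from anything measured, and a modest rise in the number is estimated. Compound 4 is therefore expected to give about 2000 nM in this assay, within a range of 600 nM to 8000 nM, a step of a 2.2-fold higher number from compound 3 to compound 4 (0.34 log units; beyond the scatter).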

Compound 4, half-maximal inhibitory concentration: > 10000 nM
Compound 4: no number, only a limit (the forecaster's own chance of this, stated with the estimate: 20%); middle value at least 5.0-fold (0.69 log units) away from the limit.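

Keeping a ring on the aromatic nitrogen does not by itself hold the activity in this assay: 1-acetylpiperidin-4-yl in place of cycloheptyl gives an at least 10-fold higher number from compound 3 to compound 4 (1.03 log units; beyond the scatter), and in place of 4-fluorobenzyl it gives an at least 8.7-fold higher number from compound 1 to compound 4 (0.94 log units; beyond the scatter). Earlier, only compound 2, with its open-chain 1-propylbutyl, stood at a limit, and compound 4 now goes against any reading that a ring on this nitrogen is enough. The steps between compound 2 and compound 4 cannot be read, as both are limits and not numbers: the limit of > 10000 nM in this assay, at which 2 of the 4 values shown sit.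

The compounds shown leave open whether the loss goes with the acetyl group, with the ring nitrogen or with the six-membered ring. A cyclohexyl group or a free piperidin-4-yl amine on this nitrogen would begin to separate these.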